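From compound 2 to compound 3: one group exchanged

The source may hold more compounds than are shown below. What is called first, only, known or untested is meant among the compounds shown, and "the series" means these compounds.

In a functional assay on HT-29 cells (Homo sapiens) for inhibition, read by MTT assay, with a stated time of 3 days (on this read-out higher numbers stand for weaker inhibition and lower numbers for stronger inhibition), compound 1 (`COc1ccc(COc2cc(/C=C\c3cc(OC)c(OC)c(OC)c3)ccc2OC)cc1`) gives 47000 nM and compound 2 (`COCOc1ccccc1/C=C/CCCOc1cc(/C=C\c2cc(OC)c(OC)c(OC)c2)ccc1OC`) gives 9600 nM. Compound 2 has the lower of the two numbers, and its gap to compound 1 lies beyond the scatter.

Compound 3 (`COc1ccc(/C=C\c2cc(OC)c(OC)c(OC)c2)cc1OCCC/C=C/c1ccc(Cl)cc1`) carries 4-chlorophenyl in place of 2-(methoxymethoxy)phenyl on a double-bonded chain carbon bound to a double-bonded chain carbon. For the measured compounds named here, no measured pair of compounds differs in one place only, so the data give no direct guide to this exchange. In this assay, a step beyond the scatter is not expected, and no firm direction can be assigned. The expected size is small (a 1.3-fold higher number from compound 2 to compound 3 (0.10 log units; within the scatter)), which keeps the expectation anchored on compound 2 at 9600 nM as the closest measured structure. Compound 3 is expected at 12000 nM within an estimated range from 4000 nM to 35000 nM as the working figure.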

Compound 3, half-maximal inhibitory concentration: 18000 nM
Compound 3: the middle estimate sits 1.5-fold (0.18 log units) below what was measured; the range from low to high includes it.
By their numbers in this assay, from the lowest: compounds 2 and 3 (each within the scatter of the next); then compound 1.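

In this assay, the step of a 1.9-fold higher number from compound 2 to compound 3 (0.27 log units; within the scatter) follows 4-chlorophenyl replacing 2-(methoxymethoxy)phenyl on a double-bonded chain carbon bound to a double-bonded chain carbon, so this read-out does not separate the two groups, although the entering group carries no hydrogen-bond acceptors. The step of a 2.6-fold lower number from compound 1 to compound 3 (0.42 log units; beyond the scatter) follows 4-(4-chlorophenyl)but-3-en-1-yl replacing 4-methoxyphenyl on a saturated chain carbon bound to an oxygen on an aromatic ring, and it is a modest change beyond the scatter. No measurement shown here accounts for either step.

Open, as far as these compounds go, is whether an amine or a carboxylic acid in place of 4-chlorophenyl would give a step beyond the scatter. From the compounds shown here alone, a longer chain carrying 4-chlorophenyl also remains open.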